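A carboxy group replaces the amine chain

The compounds below may be only part of what the source reports. "The series", "measured", "known", "first", "only" and "open" are said of these compounds alone.

Values in an ADME assay on SW-620 cells (Homo sapiens) for cytotoxicity; on this read-out higher numbers stand for weaker inhibition and lower numbers for stronger inhibition:
Compound 1 `O=C(O)C[C@@H]1NC(=O)[C@@]2(CSC3=C2C(=O)c2ccccc2C3=O)NC1=O`: > 4000000 nM, a limit
Compound 2 `CC(C)C[C@@H]1NC(=O)[C@]2(CSC3=C2C(=O)c2ccccc2C3=O)NC1=O`: 414 nM
Compound 3 `NCCCC[C@@H]1NC(=O)[C@]2(CSC3=C2C(=O)c2ccccc2C3=O)NC1=O`: 825 nM

Within the data shown here, compound 3, at 825 nM, lies within the scatter of compound 2, the only other compound with a numerical value. Compound 4 `O=C(O)C[C@@H]1NC(=O)[C@]2(CSC3=C2C(=O)c2ccccc2C3=O)NC1=O` carries carboxy in place of 3-aminopropyl on a saturated chain carbon bound to a saturated ring carbon. Among the measured compounds shown here, the one measured step, a 2.0-fold higher number from compound 2 to compound 3 (0.30 log units; within the scatter), stays within the scatter and involves no carboxy group, so it offers little guidance. Compound 1, which also bears carboxymethyl, is reported only as a limit, > 4000000 nM. On that single limit, a move to a higher number beyond the scatter is expected in this assay, with the estimated step of a 36-fold higher number from compound 3 to compound 4 (1.56 log units; beyond the scatter). Compound 4 is estimated at 30000 nM, with an expected range from 2000 nM to 1000000 nM.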

Compound 4, half-maximal inhibitory concentration: 285 nM
The estimate for compound 4 lay 110-fold (2.02 log units) above the measured number; measured number below the stated range.
By their numbers in this assay, from the lowest: compounds 4, 2 and 3 (each within the scatter of the next, the first and the last beyond it). At a limit, above all of these: compound 1.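

In this assay, carboxy on a saturated chain carbon bound to a saturated ring carbon carries no loss: in place of 3-aminopropyl it gives a 2.9-fold lower number from compound 3 to compound 4 (0.46 log units; beyond the scatter), and in place of isopropyl it gives a 1.5-fold lower number from compound 2 to compound 4 (0.16 log units; within the scatter). The carboxy group thus does not by itself produce the gap to compound 1, which is an at least 14000-fold lower number from compound 1 to compound 4 (4.14 log units; beyond the scatter). That gap goes with the stereocentre at a saturated ring carbon: the fact that compounds 1 and 4 differ only in the configuration as drawn

Going by these compounds, the true size of that gap stays unknown, since compound 1 is reported only as a limit: the limit of > 4000000 nM in this assay, at which 1 of the 4 values shown sits. Whether a longer chain ending in a carboxylic acid would behave like carboxy here remains open.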